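The source may hold more compounds than are shown below. What is called first, only, known or untested is meant among the compounds shown, and "the series" means these compounds.

Compound 1 `CNCc1c(OC)cc(Oc2cccc(Nc3ccccc3)c2)cc1OC` carries a methylamino group on the shared core. In a functional assay on HCT-15 cells (Homo sapiens) for inhibition, read by MTT assay, with a stated time of 72 h (a lower number here means a stronger inhibitor, a higher number a weaker inhibitor), compound 1 gives 8930 nM, the highest of the three numbers recorded. Compound 2 `COc1cc(Oc2cccc(Nc3ccccc3)c2)cc(OC)c1CNCc1ccc(C)cc1` gives 5400 nM and compound 3 `COc1cc(Oc2cccc(Nc3ccccc3)c2)cc(OC)c1CN[C@H](C)c1ccccc1` gives 7550 nM; the step of a 1.7-fold lower number from compound 1 to compound 2 (0.22 log units; within the scatter) and the step of a 1.2-fold lower number from compound 1 to compound 3 (0.07 log units; within the scatter) both lie within the scatter. Compound 4 `COc1cc(Oc2cccc(Nc3ccccc3)c2)cc(OC)c1CNC1CC1` differs from compound 1 by cyclopropyl in place of methyl on an amine nitrogen. Both earlier steps altered the substituent on the same amine nitrogen, and neither moved the number beyond the scatter, so for compound 4 no step beyond the scatter is expected in this assay. Compound 4 is therefore estimated at 7500 nM, with a range from 3500 nM to 16000 nM. This expectation amounts to a 1.2-fold lower number from compound 1 to compound 4 (0.08 log units; within the scatter).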

Compound 4, half-maximal inhibitory concentration: 6140 nM
For compound 4 the middle estimate is 1.2-fold (0.09 log units) above the measured one; measured number inside the range.
By their numbers in this assay, from the lowest: compounds 2, 4, 3 and 1 (each within the scatter of the next).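

In this assay, compound 4 places a cyclopropyl ring directly on the amine nitrogen, and this step too stays within the scatter (a 1.5-fold lower number from compound 1 to compound 4 (0.16 log units; within the scatter)). The same holds against the two larger groups (a 1.2-fold lower number from compound 3 to compound 4 (0.09 log units; within the scatter); a 1.1-fold higher number from compound 2 to compound 4 (0.06 log units; within the scatter)), so across these four compounds, methyl, cyclopropyl, 4-methylbenzyl and 1-phenylethyl on this nitrogen give numbers that cannot be told apart. From the compounds shown here alone, whether a carboxylic acid or a hydroxyethyl chain on this nitrogen would move the number beyond the scatter stays open. Nothing available offers an explanation for these small steps.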